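The source may hold more compounds than are shown below. What is called first, only, known or untested is meant among the compounds shown, and "the series" means these compounds.

Measured so far:
compound 1, `COc1cc(-c2nn(-c3cccc(NC(=O)Nc4ccc(Cl)c(Cl)c4)c3)cc2-c2ccncc2)ccc1Cl`: > 50000 nM
compound 2, `O=C(Nc1cccc(-n2cc(-c3ccncc3)c(-c3ccc(Cl)c(O)c3)n2)c1)Nc1ccc(Cl)c(Cl)c1`: > 32500 nM

In a functional assay on OVCAR-3 cells (Homo sapiens) for inhibition, read by sulforhodamine B assay, with a stated time of 48 h (a higher number here means that more compound is tolerated, a lower number that less compound is tolerated), compound 1 gives > 50000 nM, which is a limit of the assay and not a number. In this assay compound 2 gives > 32500 nM, again a limit rather than a number. Compound 1 therefore stands at one of two limits, with no numeric value anywhere in the set to place it against. Among the measured compounds shown here, the single measured step, a step that the two limits leave unreadable from compound 1 to compound 2, stays unreadable because of the limits the limit of > 50000 nM in this assay, at which 1 of the 2 values shown sits, and the limit of > 32500 nM in this assay, at which 1 of the 2 values shown sits, at its two ends.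

Compound 3, `COc1cc(-c2nn(-c3cccc(NC(=O)c4ccccc4)c3)cc2-c2ccncc2)ccc1Cl`, is not yet measured in this assay. Against compound 1 the change is phenyl in place of (3,4-dichlorophenyl)amino on a carbonyl carbon. For the measured compounds named here, no measured step bears on this change; the one step in hand concerns a different position and is itself unreadable. Going by the values given here, the only guide is that both measured compounds sit at limits, so compound 3 is expected to sit at a limit as well. For compound 3 the estimate in this assay is 50000 nM, within 20000 nM to 100000 nM. The step this implies, a number no higher from compound 1 to compound 3 (the limit leaves the size open), is expected to be no change that a number could show.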

Compound 3, concentration lethal to 50% of the cells: 95800 nM
Compound 3: the middle estimate sits 1.9-fold (0.28 log units) below what was measured; the measured number falls inside the stated range.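

The step from compound 1 to compound 3 cannot be read, as compound 1 stands at a limit of the assay and not at a number: the limit of > 50000 nM in this assay, at which 1 of the 3 values shown sits.

The compounds shown leave open how far phenyl in place of (3,4-dichlorophenyl)amino on a carbonyl carbon, or hydrogen in place of methyl on an oxygen on an aromatic ring, shifts the value in this assay.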